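The compounds below may be only part of what the source reports. "The series", "measured", "known", "first", "only" and "open" are said of these compounds alone.

Measured compounds, with their values in an assay for binding affinity to adenosine receptor A1 (Bos taurus); on this read-out higher numbers stand for weaker inhibition and lower numbers for stronger inhibition:

compound 1, `COc1cc(OC)cc(-c2nc3c(=O)n(C)c(=O)n(C)c3[nH]2)c1`: 500 nM
compound 2, `Cn1c(=O)c2nc(-c3ccccc3[N+](=O)[O-])[nH]c2n(C)c1=O`: 80 nM
compound 3, `Cn1c(=O)c2nc(-c3ccc([N+](=O)[O-])cc3)[nH]c2n(C)c1=O`: 8 nM

Compound 3 gives the lowest number of the three in this assay. The nearest value is that of compound 2, which lies beyond the scatter above it; the furthest is that of compound 1, also well beyond the scatter. Both compound 2 and compound 3 carry a nitro group on the pendant six-membered ring, and compound 3 carries it para to a large group.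

Compound 4, `Cn1c(=O)c2nc(-c3ccc(Cl)cc3)[nH]c2n(C)c1=O`, has not yet been measured in this assay. Compared with compound 3 it differs at one place: chloro in place of nitro on an aromatic carbon. Among the compounds with values here, the three measured compounds provide no step of this kind, so there is no measured example of a chloro replacing a nitro to lean on. What the data do show is that the nitro-bearing compound 3 gives the lowest number, so the exchange is expected to cost something rather than gain. A step from compound 3 to compound 4 of a 3.1-fold higher number from compound 3 to compound 4 (0.49 log units; beyond the scatter) is expected, modestly beyond the scatter, in the direction of a higher number. Compound 4 is accordingly estimated at 25 nM, with a range from 8 nM to 80 nM.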

Compound 4, half-maximal inhibitory concentration: 0.8 nM
The estimate for compound 4 lay 31-fold (1.49 log units) above the measured number; the measured number lies below the stated range.
By their numbers in this assay, from the lowest: compound 4; then compound 3; then compound 2; then compound 1.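

In this assay, chloro in place of nitro on this aromatic carbon, para to a large group, gives a 10-fold lower number from compound 3 to compound 4 (1.00 log units; beyond the scatter) and so moves the number down, not up. The nitro group is therefore not required at this position for a low number, and compound 4 now sets the lowest value of the series, with chloro bringing 1 heavy atom and 0 hydrogen-bond acceptors where nitro brought 3 heavy atoms and 2 hydrogen-bond acceptors. No measurement shown here bears on what lies behind the step.

This single pair cannot tell whether the position favours chloro specifically or would also accept other groups, such as fluoro, bromo, an amine or a carboxylic acid, and a series of such replacements on the same core would be needed to separate these cases. On these data alone, it also remains open whether the same exchange would give a step of similar size at another carbon of the ring, since only this one place has a matched pair.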